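Shrinking Cyclopropyl to Methyl: From Compound 2 to Compound 3

The source may report more compounds than this note shows. Statements on the series, on what has been measured and on what is new or still open speak of the compounds shown alone.

compound 1 `COc1ccc([C@@H]2C/C(=N\O)c3c(O)cc(OCc4cn(Cc5ccccc5F)nn4)cc3O2)cc1O`: 5710 nM
compound 2 `COc1ccc([C@@H]2CC(=O)c3c(O)cc(OCc4cn(CC5CC5)nn4)cc3O2)cc1O`: 11900 nM

Both were tested in a functional assay on RAW264.7 cells (Mus musculus) for inhibition, read by Griess assay, with stated times of 2 h and 24 h; a higher number here means a weaker inhibitor, a lower number a stronger inhibitor. Of the two numbers, compound 2 gives the higher one; compound 1 sits lower by a gap beyond the usual scatter. Compound 3 `CCn1cc(COc2cc(O)c3c(c2)O[C@H](c2ccc(OC)c(O)c2)CC3=O)nn1` differs from compound 2 in one place: methyl in place of cyclopropyl on a saturated chain carbon bound to an aromatic nitrogen. Going by the values given here, no measured pair shows this particular change, so there is no measured step to lean on. The change is small, and compound 3 is expected to stay close to compound 2, with a step of a 1.0-fold higher number from compound 2 to compound 3 (0.00 log units; within the scatter) that lies within the scatter. The estimate for compound 3 is 12000 nM, in a range from 5000 nM to 30000 nM.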

Compound 3, half-maximal inhibitory concentration: 15000 nM
The estimate for compound 3 lay 1.3-fold (0.10 log units) below the measured number; the range from low to high includes it.
By their numbers in this assay, from the lowest: compound 1; then compounds 2 and 3 (each within the scatter of the next).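

Putting methyl in place of cyclopropyl on a saturated chain carbon bound to an aromatic nitrogen gives a 1.3-fold higher number from compound 2 to compound 3 (0.10 log units; within the scatter) in this assay. In this read-out, the two compounds cannot be told apart, whether the three-membered ring is present or not. Nothing on hand explains this result. The compounds shown leave open whether an amine, a carboxylic acid or a longer chain at this place would shift the number beyond the scatter. They also leave open whether this same swap would give a similar result on the core of compound 1.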